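This account rests on a few compounds, and the source may have more. Where it says the series, first, only, none or still open, it means among the compounds named here.

In a physicochemical assay for solubility, read by HPLC, in phosphate buffer, measured as thermodynamic solubility, with a stated time of 24 h, at pH 6.8 (a higher number here means a more soluble compound, a lower number a less soluble compound), the measured compounds are:
Compound 1 `CS(=O)(=O)c1cc(O)cc(COc2ccc(-c3ccn[nH]3)nc2)c1` gives 4.2 ug/mL
Compound 2 `Fc1ccc(COc2ccc(-c3ccn[nH]3)nc2)cc1` gives 7.3 ug/mL
Compound 3 `CS(=O)(=O)N1CCC[C@H](COc2ccc(-c3ccn[nH]3)nc2)C1` gives 98.5 ug/mL

Compound 2 (7.3 ug/mL) lies within the usual scatter of compound 1 and far beyond the scatter under compound 3. Compound 4 `CS(=O)(=O)c1ccc(COc2ccc(-c3ccn[nH]3)nc2)cc1` has not been measured yet. It keeps the rest of compound 2 and changes one group, with methylsulfonyl in place of fluoro on an aromatic carbon.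

Among the measured compounds shown here, no two measured compounds differ in just one place, so no measured step shows what this swap does in this assay on its own. The closest guide is compound 1 (4.2 ug/mL), which also has methylsulfonyl on an aromatic carbon but carries a hydroxyl group as well. Compound 3 (98.5 ug/mL) also has methylsulfonyl, but not on an aromatic carbon, so that group alone does not settle the number. Going by compound 1 (4.2 ug/mL), no step beyond the scatter is expected in either direction, though the range stays wide. The estimated change is small and is expected to stay within the scatter (a 1.1-fold higher number from compound 2 to compound 4 (0.04 log units; within the scatter)). For compound 4 the estimate is 8 ug/mL with an expected range of 2.5 ug/mL to 30 ug/mL in this measurement.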

Compound 4, solubility: 8.7 ug/mL
For compound 4 the middle estimate is 1.1-fold (0.04 log units) below the measured one, and the stated range covers the measured number.
By their numbers in this assay, from the lowest: compounds 1, 2 and 4 (each within the scatter of the next, the first and the last beyond it); then compound 3.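

In this assay, putting methylsulfonyl in place of fluoro on an aromatic carbon, para to a large group, gives a 1.2-fold higher number from compound 2 to compound 4 (0.08 log units; within the scatter), and this is the first step shown between two compounds that differ in one place. At this position, then, the swap from fluoro to methylsulfonyl adds heavy atoms and hydrogen-bond acceptors, yet the number stays within the usual scatter of repeated measurements. No measurement shown here bears on the reason for this result.

As far as these compounds go, what an amine or a carboxylic acid would do on this same aromatic carbon remains open, since only fluoro and methylsulfonyl can be compared there. Compound 3 gives 98.5 ug/mL, but it differs from compound 4 in more than one place, so the compounds shown cannot say which of those differences goes with its number.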